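The source may report more compounds than this note shows. Statements on the series, on what has been measured and on what is new or still open speak of the compounds shown alone.

Compound 1 `O=C(O)/C=C/c1ccc(NC(=O)C2(NC(=O)c3ccc4c(c3)nc(-c3ccccc3)n4C3CCCCC3)CCC2)cc1` and compound 2 `O=C(O)/C=C/c1ccc(NC(=O)C2(NC(=O)c3ccc4c(c3)nc(-c3ccsc3)n4C3CCCCC3)CCC2)cc1` share one core and differ in a single place, the change being a thiophen-3-yl in place of a phenyl on an aromatic carbon. In an ADME assay on Huh-7 cells (Homo sapiens) for cytotoxicity (a higher number here means that more compound is tolerated, a lower number that less compound is tolerated), compound 1 gives > 10 uM, which is a limit of the assay rather than a number. In this assay compound 2 gives > 10 uM, again a limit rather than a measured number. The step that the two limits leave unreadable from compound 1 to compound 2 therefore cannot be read in size or direction. Both shown values sit at the limit of > 10 uM in this assay, at which 2 of the 2 values shown sit, so compound 2 stands at the limit, with no number to place it above or below compound 1.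

Compound 3 `O=C(O)/C=C/c1ccc(NC(=O)C2(NC(=O)c3ccc4c(c3)nc(-c3cccs3)n4C3CCCCC3)CCC2)cc1` has not yet been measured in this assay. It differs from compound 2 by thiophen-2-yl in place of thiophen-3-yl on an aromatic carbon. Within the data shown here, no measured step speaks directly to this change, and the one step that is known, a step that the two limits leave unreadable from compound 1 to compound 2, is unreadable. Because both measured values sit at the limit of > 10 uM in this assay, at which 2 of the 2 values shown sit, compound 3 is expected to remain at that limit as well, so the step that the limit leaves unreadable from compound 2 to compound 3 is expected to show no size beyond the scatter. Compound 3 is accordingly estimated at 15 uM, within a range from 8 uM to 40 uM.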

Compound 3, half-maximal toxic concentration: > 10 uM
Compound 3 was reported as a limit; the forecaster's own chance of this, stated with the estimate: 85%; the middle value lies beyond the limit too.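

No step from compound 1 or compound 2 to compound 3 can be read in size or direction, as all three compounds stand at the same limit of the assay: the limit of > 10 uM in this assay, at which 3 of the 3 values shown sit.

The compounds shown leave open whether compound 1, compound 2 and compound 3 differ at all in this assay, and at what concentration each becomes toxic to the cells.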